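Ester to Acid at the Edge of the Assay

The compounds below may be only part of what the source reports. "The series", "measured", "known", "first", "only" and "open" are said of these compounds alone.

Compound 1 `CCOC(=O)C1=Cc2ccccc2OC1(OCc1cc(-c2ccc(F)cc2F)no1)C(F)(F)F` stands at the weak end of what was measured. In a functional assay on MCF7 cells (Homo sapiens) for inhibition, read by MTT assay, with a stated time of 24 h (on this read-out higher numbers stand for weaker inhibition and lower numbers for stronger inhibition), compound 1 gives > 150000 nM, a limit of the assay rather than a number. Compound 2 `CCOC(=O)C1=Cc2ccccc2OC1(OCc1cc(-c2ccc3ccccc3c2)no1)C(F)(F)F` gives 65400 nM in this assay. Compound 3 `CCOC(=O)C1=Cc2ccccc2OC1(OCc1cc(-c2ccc(OC)cc2)no1)C(F)(F)F` gives > 150000 nM in this assay, again a limit. The measured steps all change the aryl group: an at least 2.2-fold lower number from compound 1 to compound 2 (0.36 log units; beyond the scatter), an at least 2.2-fold higher number from compound 2 to compound 3 (0.36 log units; beyond the scatter), and a step that the two limits leave unreadable from compound 1 to compound 3. Compound 4 `O=C(O)C1=Cc2ccccc2OC1(OCc1cc(-c2ccc(F)cc2F)no1)C(F)(F)F` differs from compound 1 elsewhere: hydrogen in place of ethyl on an oxygen next to a carbonyl group. Among the measured compounds shown here, none of the measured steps touches this place, so none bears on it; the only anchor is compound 1 at the limit of > 150000 nM in this assay, at which 2 of the 3 values shown sit. Compound 4 is therefore expected to stay near that limit, with a step that the limit leaves unreadable from compound 1 to compound 4 expected to fall within the scatter. The estimate for compound 4 is 200000 nM, ranging from 80000 nM to 600000 nM.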

Compound 4, half-maximal inhibitory concentration: > 150000 nM
Compound 4 ended at the assay's limit (the forecaster's own chance of this, stated with the estimate: 80%); the middle value does not contradict the limit.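

Compound 1 and compound 4 both end at a limit, so the step between them cannot be read: the limit of > 150000 nM in this assay, at which 3 of the 4 values shown sit.

On these data alone, what hydrogen in place of ethyl does to a compound with a readable value, such as compound 2, stays open.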